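The source may hold more compounds than are shown below. What is called first, only, known or untested is meant among the compounds shown, and "the series" means these compounds.

Of the three compounds measured in a functional assay on the whole organism with Homo sapiens as the target, read by calcium flux (a lower number here means a stronger inhibitor, a higher number a weaker inhibitor), compound 3 `O=C(O)/C=C/c1nc(CSCc2cccc(C(=O)O)c2)ccc1OCCCCCCCCc1ccccc1` stands second highest, giving 320 nM; compound 1 `COc1ccc(CCCCCCCCOc2ccc(CSc3cccc(C(=O)O)c3)nc2/C=C/C(=O)O)cc1` gives 550 nM, and compound 2 `COc1ccc(CCCCCCCCOc2ccc(CSCc3cccc(C(=O)O)c3)nc2/C=C/C(=O)O)cc1` gives 131 nM. The step of a 4.2-fold lower number from compound 1 to compound 2 (0.62 log units; beyond the scatter) was modest, as was the step of a 2.4-fold higher number from compound 2 to compound 3 (0.39 log units; beyond the scatter). Compound 4 `COc1ccc(CCCCOc2ccc(CSCc3cccc(C(=O)O)c3)nc2/C=C/C(=O)O)cc1` differs from compound 3 by 4-methoxyphenyl in place of 4-phenylbutyl on a saturated chain carbon, four bonds along the chain from an oxygen on an aromatic ring. Only the methoxy part of this change has a measured counterpart, the step of a 2.4-fold higher number from compound 2 to compound 3 (0.39 log units; beyond the scatter), whose reversal would argue for a somewhat lower number; the shortening of the chain has no measured precedent among these compounds. Compound 4 is therefore expected to show a small step, a 1.3-fold lower number from compound 3 to compound 4 (0.11 log units; within the scatter), in this assay, estimated at 250 nM, with a range from 60 nM to 1200 nM.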

Compound 4, half-maximal inhibitory concentration: 770 nM
Compound 4: the middle estimate sits 3.1-fold (0.49 log units) below what was measured; the measured number falls inside the stated range.
By their numbers in this assay, from the lowest: compound 2; then compounds 3, 1 and 4 (each within the scatter of the next, the first and the last beyond it).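

In this assay, shortening the chain while the methoxy stays in place gives a 5.9-fold higher number from compound 2 to compound 4 (0.77 log units; beyond the scatter), so the length of the chain at this position matters on its own. The methoxy does not make up for the shorter chain, since the combined change gives a 2.4-fold higher number from compound 3 to compound 4 (0.38 log units; beyond the scatter). No measurement at hand explains why the chain length matters.

The compounds shown leave open how the number moves with a chain of intermediate length, or with a longer chain than that of compound 2. They also leave open whether an amine or a hydroxyl in place of the methoxy would behave alike.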